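This account rests on a few compounds, and the source may have more. Where it says the series, first, only, none or still open, it means among the compounds named here.

Measured in an ADME assay on MRC5 cells (Homo sapiens) for inhibition, read by MTT assay, with a stated time of 72 h; a higher number here means a weaker inhibitor, a lower number a stronger inhibitor:
- Compound 1 `O=C(OCCCCCCO)OCCc1ccc(O)c(O)c1`: > 50000 nM, a limit of the assay
- Compound 2 `CCCCOC(=O)OCCc1ccc(O)c(O)c1`: "not determined" (no result reported)
- Compound 3 `CCCCCCCCCCCCOC(=O)OCCc1ccc(O)c(O)c1`: 12400 nM

Compound 2 therefore has no number of its own in this assay, and any step away from it can only be judged indirectly. Going by the values given here, the one other reading that is not a plain number is the limit of > 50000 nM in this assay, at which 1 of the 3 values shown sits. The change from compound 2 to compound 4 `O=C(OCCc1ccc(O)c(O)c1)OCCc1ccc(O)c(O)c1` is 3,4-dihydroxyphenyl in place of ethyl on a saturated chain carbon, two bonds along the chain from an oxygen next to a carbonyl group: 3,4-dihydroxyphenyl in place of ethyl, on a saturated chain carbon, two bonds along the chain from an oxygen next to a carbonyl group.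

Among the compounds with values here, only one measured step bears on this, and it concerns a different change. That step is an at least 4.0-fold lower number from compound 1 to compound 3 (0.60 log units; beyond the scatter), where hexyl replaces hydroxy on a saturated chain carbon, and it lies beyond the scatter. Compound 4 does not gain such a hexyl extension, and its new group carries hydroxy groups, as the chain of compound 1 does. With no value for compound 2, no firm step size can be expected, but the number for compound 4 is expected to lie closer to the limit seen for compound 1 than to the value of compound 3. In this assay, the expected value for compound 4 is an estimated 40000 nM, ranging from 15000 nM to 100000 nM.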

Compound 4, half-maximal inhibitory concentration: > 50000 nM
Compound 4: no number, only a limit (the forecaster's own chance of this, stated with the estimate: 55%); middle value at least 1.2-fold (0.09 log units) away from the limit.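

Compound 4 gives > 50000 nM in this assay, which is a limit of the assay, so no new step can be read from it, neither against compound 1 nor against compound 2. The compounds shown leave open how far apart compound 1 and compound 4 lie in this assay, and how compound 2 compares with either.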